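Amino for Chloro on the Core of Compound 1

A few compounds are considered here, and "the series" means these few. Any claim that something is new, unique, unknown or untested is made for them only; others in the source may bear on it.

Measured compounds:
compound 1 `ClCc1ccccc1Cn1cnc2c(Cl)nc(Cl)nc21`: 1230 nM
compound 2 `ClCc1ccc(Cn2cnc3c(Cl)nc(Cl)nc32)cc1`: 20000 nM

In a functional assay on OVCAR-8 cells (Homo sapiens) for cytotoxicity, read by sulforhodamine B assay, with a stated time of 48 h (on this read-out higher numbers stand for weaker inhibition of growth and lower numbers for stronger inhibition of growth), compound 1 gives 1230 nM, the lowest of the two numbers; compound 2 gives 20000 nM, a gap beyond the scatter. Compound 3 `Nc1nc(Cl)c2ncn(Cc3ccccc3CCl)c2n1` differs from compound 1 in one place: amino in place of chloro on an aromatic carbon, an amino in place of chloro on an aromatic carbon. Within the data shown here, no step of this kind has been measured here, so the size rests on expectation alone. Compound 3 is expected to sit somewhat higher than compound 1, a step of a 2.4-fold higher number from compound 1 to compound 3 (0.39 log units; beyond the scatter) that may just exceed the scatter, at an estimated 3000 nM within 800 nM to 12000 nM.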

Compound 3, concentration for 50% growth inhibition: 3890 nM
The estimate for compound 3 lay 1.3-fold (0.11 log units) below the measured number; the range from low to high includes it.
By their numbers in this assay, from the lowest: compound 1; then compound 3; then compound 2.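

In this assay the replacement of chloro by amino on the aromatic carbon between two ring nitrogen atoms gives a 3.2-fold higher number from compound 1 to compound 3 (0.50 log units; beyond the scatter) and counts as a modest step. This position therefore responds to the change, but the step is small enough that growth inhibition is weakened rather than lost. No measurement at hand accounts for the step. Open, on these data alone, is how a methylamino or a methoxy group would fare at this position. Also open, as far as these compounds go, is what an amino group would do in place of the chloro group that remains on the shared core.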